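From compound 1 to compound 4: plasma protein binding

The source may report more compounds than this note shows. Statements on the series, on what has been measured and on what is new or still open speak of the compounds shown alone.

Measured in an ADME assay on a cell-free system (plasma, Homo sapiens) for protein binding, read by LC-MS, with a stated time of 5 h, tested at 10 uM:
compound 1 `OC[C@H]1O[C@H](Oc2ccc(-n3ccc4ccccc43)cc2Cl)[C@@H](O)[C@@H](O)[C@@H]1O`: 98%
compound 2 `COc1ccc2c(ccn2-c2ccc(O[C@H]3O[C@H](CO)[C@@H](O)[C@H](O)[C@@H]3O)c(Cl)c2)c1`: 96%
compound 3 `CS(=O)(=O)Nc1ccc2c(ccn2-c2ccc(O[C@H]3O[C@H](CO)[C@@H](O)[C@H](O)[C@@H]3O)c(Cl)c2)c1`: 94%

Compound 1 stands at 98%. Its nearest measured neighbour is reached by a 2.0-fold higher unbound fraction from compound 1 to compound 2 (0.30 log units; within the scatter). Its furthest is reached by a 3.0-fold higher unbound fraction from compound 1 to compound 3 (0.48 log units; beyond the scatter). The remaining pair shows a 1.5-fold higher unbound fraction from compound 2 to compound 3 (0.18 log units; within the scatter).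

The next compound is compound 4 `OC[C@H]1O[C@H](Oc2ccc(N3CCc4ccccc43)cc2Cl)[C@@H](O)[C@@H](O)[C@@H]1O`, which differs from compound 1 at one place: 2,3-dihydro-1H-indol-1-yl in place of 1H-indol-1-yl on an aromatic carbon. The exchange is 2,3-dihydro-1H-indol-1-yl in place of 1H-indol-1-yl, on an aromatic carbon.

Going by the values given here, no measured step makes this exchange. The three steps available swap hydrogen, methoxy and methanesulfonamido on an aromatic carbon and leave 1H-indol-1-yl itself in place, so they bear on it only as a guide to how far values move in this series. The largest of them, a 3.0-fold higher unbound fraction from compound 1 to compound 3 (0.48 log units; beyond the scatter), is modest, and the data give no direction for the new exchange. No step beyond the scatter is therefore expected in this assay. The expected step is a 1.5-fold higher unbound fraction from compound 1 to compound 4 (0.18 log units; within the scatter). For compound 4 the estimated value is 97%, with an expected range of 94% to 99%.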

Compound 4, plasma protein binding: 99%
Beside the measured number, compound 4's estimate is 3.0-fold (0.48 log units) (unbound fraction) above it; the range from low to high includes it.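

Working notes on this position: in this assay the exchange of 1H-indol-1-yl for 2,3-dihydro-1H-indol-1-yl gives a 2.0-fold lower unbound fraction from compound 1 to compound 4 (0.30 log units; within the scatter) and so stays within the usual scatter. The earlier steps shown here changed only a substituent while 1H-indol-1-yl stayed in place, whereas this pair alters the group itself, with a five-membered non-aromatic ring entering for a five-membered aromatic ring and the counts of heavy atoms, donors and acceptors unchanged. For this single pair, on an aromatic carbon para to a large group and meta to a chloro group, loss of aromaticity in the five-membered ring therefore brings no step beyond the scatter in this assay and no supporting data bear on why the two values lie so close.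

As far as these compounds go, it remains open whether the methoxy and methanesulfonamido exchanges would give similar steps on 2,3-dihydro-1H-indol-1-yl as on 1H-indol-1-yl. Also open, from the compounds shown here alone, is whether a piperidine ring or a carboxylic acid at this place would give a larger step in the unbound fraction than any seen so far.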